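This account rests on a few compounds, and the source may have more. Where it says the series, first, only, none or still open, it means among the compounds named here.

Series notes. Compound 1 `COc1ccc(NS(=O)(=O)c2ccc(N3CCNC3=O)cc2)cc1` gives 580 nM in a functional assay on M21 cells (Homo sapiens) for antiproliferative activity, read by sulforhodamine B assay, with a stated time of 48 h; a higher number here means a weaker inhibitor, a lower number a stronger inhibitor. Compound 3 `O=C1NCCN1c1ccc(S(=O)(=O)Nc2cccc(Cl)c2)cc1` gives 25 nM in this assay, the step being a 23-fold lower number from compound 1 to compound 3 (1.37 log units; beyond the scatter). For compound 2 `CC(C)Cc1ccc(NS(=O)(=O)c2ccc(N3CCNC3=O)cc2)cc1` this assay reports only a limit, > 1000 nM (the limit of > 1000 nM in this assay, at which 1 of the 3 values shown sits); compound 2 therefore stands without a number of its own, and the step of an at least 1.7-fold higher number from compound 1 to compound 2 (0.23 log units; that floor lies within the scatter) is only a floor. Compound 4 `O=C1NCCN1c1ccc(S(=O)(=O)Nc2ccccc2)cc1` differs from compound 2 by hydrogen in place of isobutyl on an aromatic carbon. Going by the values given here, both measured steps bear on this: the one ending at compound 2 is a floor inside the scatter, the one ending at compound 3 is large. A lower number is expected for compound 4 because compound 1 gives 580 nM and compound 3 gives 25 nM without an isobutyl, so the step of an at least 4.0-fold lower number from compound 2 to compound 4 (0.60 log units; beyond the scatter) is expected. Compound 4 is estimated at 250 nM, within 60 nM to 1000 nM.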

Compound 4, half-maximal inhibitory concentration: 200 nM
Compound 4: middle estimate off by 1.3-fold (0.10 log units), on the high side; the measured number falls inside the stated range.
By their numbers in this assay, from the lowest: compound 3; then compound 4; then compound 1. At a limit, above all of these: compound 2.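

Against hydrogen, the substituent effect in this assay runs both ways: hydrogen in place of chloro gives an 8.0-fold higher number from compound 3 to compound 4 (0.90 log units; beyond the scatter), while hydrogen in place of methoxy gives a 2.9-fold lower number from compound 1 to compound 4 (0.46 log units; beyond the scatter). Hydrogen in place of isobutyl gives an at least 5.0-fold lower number from compound 2 to compound 4 (0.69 log units; beyond the scatter), which is only a floor, so methoxy and isobutyl both stand on the higher side of hydrogen and chloro on the lower side. Compound 2 stands at a limit, not a number: the limit of > 1000 nM in this assay, at which 1 of the 4 values shown sits.

On these data alone, how an amine or a hydroxyl on this aromatic carbon would compare with hydrogen stays open. Also open, as far as these compounds go, is whether chloro keeps its lower number when para to a large group.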